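Ureido for Methyl: Compound 2 to Compound 3

This account rests on a few compounds, and the source may have more. Where it says the series, first, only, none or still open, it means among the compounds named here.

Going by the values given here, compound 2 `Cc1ncc(-c2ccccc2)c(C(C)(C)C)n1` is the only compound with a number in a functional assay on the whole organism for inhibition, with Rattus norvegicus as the target, with stated times of 1 h and 3.5 h, at a dose of 100 mg/kg by the oral route (a higher number here means more inhibition at the dose given (going by the name of the read-out), a lower number less inhibition), where compound 2 gives 22%. Compound 1 `N#CNc1nccc(-c2ccncc2)n1` gives < 5% in this assay, which is a limit of the assay rather than a number; (the limit of < 5% in this assay, at which 1 of the 2 values shown sits). Compound 3 `CC(C)(C)c1nc(NC(N)=O)ncc1-c1ccccc1` has not been measured; it differs from compound 2 by ureido in place of methyl on an aromatic carbon. Among the compounds with values here, no measured step covers this change, so compound 3 is expected to sit near its parent, with an expected step of a number 2 percentage points lower from compound 2 to compound 3 (within the scatter) that stays within the scatter. Compound 3 is therefore estimated at 20% in this assay, with a range from 5% to 45%.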

Compound 3, a percentage reported as inhibition, in the whole organism at one dose (the size of the read-out at that dose, not a potency): 14%
Compound 3: the middle estimate sits 6 percentage points above what was measured; the measured number falls inside the stated range.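

In this assay, ureido can stand in place of methyl at the position between two ring nitrogen atoms without a change beyond the scatter: the step is a number 8 percentage points lower from compound 2 to compound 3 (within the scatter). This is the only step shown between compounds that differ in one place, and it gives this position its first reading, with no separation of compound 3 from compound 2. Nothing shown here bears on why these two compounds lie this close. From the compounds shown here alone, whether an amine, a carboxylic acid or a longer chain at this position would give a step beyond the scatter remains open.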